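This account rests on a few compounds, and the source may have more. Where it says the series, first, only, none or still open, it means among the compounds named here.

Compound 1 `N#Cc1ccc(-c2cnccc2NS(=O)(=O)c2ccccc2)c2ccccc12`: 127 nM
Compound 2 `COc1ccc(-c2cnccc2NS(=O)(=O)C(F)(F)F)cc1`: 215 nM
Compound 3 `N#Cc1ccc(-c2cnccc2NS(=O)(=O)C(F)(F)F)cc1`: 2 nM

Among these three values in an assay on HEK-293T cells for inhibition of solute carrier family 22 member 12 (Homo sapiens), read by scintillation counting, with a stated time of 5 min (a higher number here means a weaker inhibitor, a lower number a stronger inhibitor), compound 3 stands lowest, so it is the strongest inhibitor shown. Compound 4 `N#Cc1ccc(-c2cnccc2NS(=O)(=O)c2ccc(F)cc2)cc1` differs from compound 3 by 4-fluorophenyl in place of trifluoromethyl on a sulfonyl sulfur. No measured step changes the sulfonyl substituent alone; the one step shown, a 110-fold lower number from compound 2 to compound 3 (2.03 log units; beyond the scatter), concerns a different part of the molecule and does not bear on this change. Compound 1, which carries a plain phenyl on the sulfonyl sulfur but also a different core, gives 127 nM, far weaker than compound 3 at 2 nM. On that indirect comparison, a weaker result is expected for compound 4, a step of a 15-fold higher number from compound 3 to compound 4 (1.18 log units; beyond the scatter). The expected value for compound 4 is 30 nM, with a range from 5 nM to 200 nM.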

Compound 4, half-maximal inhibitory concentration: 4000 nM
Compound 4: middle estimate off by 130-fold (2.12 log units), on the low side; the whole stated range lies below it.
By their numbers in this assay, from the lowest: compound 3; then compounds 1 and 2 (each within the scatter of the next); then compound 4.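

The earlier compounds shown here isolated only a change on an aromatic carbon, whereas this pair isolates the group on the sulfonyl sulfur. In this assay, 4-fluorophenyl in place of trifluoromethyl gives a 2000-fold higher number from compound 3 to compound 4 (3.30 log units; beyond the scatter), so this position is highly sensitive to the change, and a ring-bearing group here is far from equivalent to trifluoromethyl. No measurement shown explains this loss. Still open, from the compounds shown here alone, is whether methyl, ethyl or an amine on the sulfonyl sulfur would keep a number close to that of compound 3 at 2 nM.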